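A few compounds are considered here, and "the series" means these few. Any claim that something is new, unique, unknown or untested is made for them only; others in the source may bear on it.

Measured compounds:
- Compound 1 `Cc1nc(NC(=O)NCc2ccccc2)c2nn(-c3ccccc3)cc2n1` gives 26% in an assay on CHO cells for displacement of a labelled ligand from adenosine receptor A1 (Homo sapiens), read by scintillation counting, with a stated time of 120 min, tested at 1 uM; a lower number here means less inhibition, a higher number more inhibition at the concentration tested (going by the name of the read-out).
- Compound 2 `O=C(Nc1nc(-c2ccccc2)nc2cn(-c3ccccc3)nc12)c1ccco1` gives 11% in this assay.
- Compound 3 `COc1ccc(-n2cc3nc(C)nc(NC(=O)NCc4ccccc4)c3n2)cc1` gives 8% in this assay.

Compound 1 stands highest of the three measured numbers. Within the data shown here, its nearest neighbour is compound 2, whose number is lower by more than the scatter, and furthest is compound 3, reached by the one measured step, a number 18 percentage points lower from compound 1 to compound 3 (beyond the scatter), a modest fall from methoxy in place of hydrogen on an aromatic carbon.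

Compound 4 `Cc1nc(NC(=O)c2cccnc2)c2nn(-c3ccccc3)cc2n1` is not yet measured. It differs from compound 1 in one place: pyridin-3-yl in place of benzylamino on a carbonyl carbon. Among the measured compounds shown here, no measured step addresses this change directly, since the only step recorded concerns a substituent on an aromatic carbon, not the carbonyl carbon. For the measured compounds named here, compound 2, the only measured compound that carries an aromatic ring directly on its carbonyl carbon, differs from compound 1 in two places, so its lower number can only hint at the direction. On that thin basis a fall of modest size is expected, a number 11 percentage points lower from compound 1 to compound 4 (beyond the scatter), with a real chance of no change beyond the scatter. Compound 4 is therefore estimated at 15% in this assay, within a range from 3% to 30%.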

Compound 4, a percentage reported as inhibition, at one concentration (the size of the read-out at that concentration, not a potency): 12%
The estimate for compound 4 lay 3 percentage points above the measured number, within the range that was stated.
By their numbers in this assay, from the lowest: compounds 3, 2 and 4 (each within the scatter of the next); then compound 1.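

In this assay, pyridin-3-yl in place of benzylamino on a carbonyl carbon gives a number 14 percentage points lower from compound 1 to compound 4 (beyond the scatter), the first direct reading at this position, and alongside a number 18 percentage points lower from compound 1 to compound 3 (beyond the scatter) it means that both single changes shown from compound 1, at two different places, give lower numbers. The change at the carbonyl carbon alters several things at once: a six-membered aromatic ring of carbon only gives way to one with a hetero atom, and the hydrogen-bond donor of benzylamino leaves while a hydrogen-bond acceptor enters, so this one step cannot separate their contributions. No measurement shown here accounts for the fall.

The compounds shown leave open whether the loss follows the ring nitrogen or the loss of the amino link, which phenyl or pyridin-3-ylmethylamino on the same carbonyl carbon could help to separate. They also leave open whether a longer chain such as phenethylamino, or a saturated amine such as morpholine, would hold this position at the level of compound 1 or take it lower still.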